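The source may report more compounds than this note shows. Statements on the series, on what has been measured and on what is new or still open speak of the compounds shown alone.

Measured compounds:
- compound 1, `O=C(Nc1ccc(S(=O)(=O)Nc2ccccc2)cc1)c1ccc(Cl)cc1F`: 3980 nM
- compound 2, `O=C(Nc1ccc(S(=O)(=O)Nc2ccccc2)cc1)c1ccc(Br)cc1F`: 479 nM
- compound 3, `O=C(Nc1ccc(S(=O)(=O)Nc2ccccc2)cc1)c1ccc(C(F)(F)F)cc1F`: 363 nM

These three share one core and differ only in the group on the carbonyl carbon. In a functional assay on HEK293 cells for agonist activity at probable G-protein coupled receptor 27 (Homo sapiens), read by a luciferase reporter and beta-arrestin recruitment, with a stated time of 10 min (on this read-out lower numbers stand for an effect already at smaller amounts and higher numbers for an effect only at larger amounts of compound), compound 2 gives the second highest of the three numbers: its nearest neighbour is compound 3, and the step of a 1.3-fold lower number from compound 2 to compound 3 (0.12 log units; within the scatter) lies within the scatter, so the two cannot be told apart; its furthest neighbour is compound 1, reached by the step of an 8.3-fold lower number from compound 1 to compound 2 (0.92 log units; beyond the scatter) in the other direction.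

Compound 4, `O=C(Nc1ccc(S(=O)(=O)Nc2ccccc2)cc1)c1cc(F)c(Cl)cc1F`, is not yet measured. The change from compound 2 is 4-chloro-2,5-difluorophenyl in place of 4-bromo-2-fluorophenyl on a carbonyl carbon. Among the measured compounds shown here, the entering group carries a chlorine, as in compound 1, together with a second fluorine that none of the measured compounds has. For the measured compounds named here, the one step that bears on this is an 8.3-fold lower number from compound 1 to compound 2 (0.92 log units; beyond the scatter), a modest but clear drop when bromo replaced chloro; the added fluorine has no measured counterpart. For compound 4 the step of a 4.2-fold higher number from compound 2 to compound 4 (0.62 log units; beyond the scatter) is therefore expected, a rise toward the value of compound 1, with wide uncertainty. Compound 4 is estimated at 2000 nM, in a range from 500 nM to 8000 nM.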

Compound 4, half-maximal effective concentration: 141 nM
Estimate against measurement, compound 4: 14-fold (1.15 log units) above; measured number outside the range, below it.
By their numbers in this assay, from the lowest: compound 4; then compounds 3 and 2 (each within the scatter of the next); then compound 1.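

In this assay, the step of a 28-fold lower number from compound 1 to compound 4 (1.45 log units; beyond the scatter) comes from a single fluoro in place of hydrogen on an aromatic carbon, so a ring carbon that carries only hydrogen in compound 1 turns out to matter greatly for this read-out. The step of a 3.4-fold lower number from compound 2 to compound 4 (0.53 log units; beyond the scatter) brings in 4-chloro-2,5-difluorophenyl in place of 4-bromo-2-fluorophenyl and so changes two things at once, the halogen and the extra fluoro. Set against the step of an 8.3-fold lower number from compound 1 to compound 2 (0.92 log units; beyond the scatter) in the other direction, it shows that the chloro group of compound 1 does not by itself fix a high number, since the extra fluoro more than makes up the difference. Nothing available explains the size of either step.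

From the compounds shown here alone, whether the same extra fluoro would lower the number as much on the bromo group of compound 2 or the trifluoromethyl group of compound 3 remains open. Also open, going by these compounds, is what a methoxy group, a nitrile or an amine would do on that same ring carbon in place of fluoro.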